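Cyclopropylcarbonyl in place of cyclopropylmethyl: clearance outlook

This account rests on a few compounds, and the source may have more. Where it says the series, first, only, none or still open, it means among the compounds named here.

Measured in an ADME assay on microsomes from liver (Rattus norvegicus) for pharmacokinetics; on this read-out lower numbers stand for slow clearance and higher numbers for fast clearance:
- compound 1 `CCC(=O)N1CCN(c2nc(-c3cnn(C)c3)ncc2C#N)C[C@H]1C` gives < 36 mL/min/kg, a limit of the assay
- compound 2 `C[C@@H]1CN(c2nc(-c3cnn(C)c3)ncc2C#N)CCN1C(=O)C1CC1` gives < 36 mL/min/kg, a limit of the assay
- compound 3 `Cn1cc(-c2ncc(C#N)c(N3C[C@@H]4C[C@H]3CN4CC3CC3)n2)cn1` gives 158 mL/min/kg

For the measured compounds named here, compound 3 carries the only number in this assay; the two other values sit at the limit (the limit of < 36 mL/min/kg in this assay, at which 2 of the 3 values shown sit). Going by the values given here, the single measured step, a step that the two limits leave unreadable from compound 1 to compound 2, is unreadable and concerns a carbonyl carbon, so no measured step bears on the change to compound 4 `Cn1cc(-c2ncc(C#N)c(N3C[C@@H]4C[C@H]3CN4C(=O)C3CC3)n2)cn1`. That change is cyclopropylcarbonyl in place of cyclopropylmethyl on an amine nitrogen in a ring. Compound 1 and compound 2 each carry a carbonyl on a ring nitrogen; compound 3 carries cyclopropylmethyl on the amine nitrogen in a ring. On that basis compound 4 is expected to show a downward step of a 4.0-fold lower number from compound 3 to compound 4 (0.60 log units; beyond the scatter) in this assay. The estimate for compound 4 is 40 mL/min/kg, between 15 mL/min/kg and 100 mL/min/kg, with a real chance of a limit only.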

Compound 4, clearance: < 36 mL/min/kg
Compound 4: no number, only a limit; the forecaster's own chance of this, stated with the estimate: 40%; at least 1.1-fold (0.04 log units) between middle value and limit.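

In this assay, for the compounds shown here, cyclopropylcarbonyl in place of cyclopropylmethyl on an amine nitrogen in a ring gives an at least 4.3-fold lower number from compound 3 to compound 4 (0.64 log units; beyond the scatter), the only readable step. Compound 4 gives < 36 mL/min/kg, which is a limit of the assay and not a number. The step between compound 1 and compound 2 cannot be read, so this pair alone links a carbonyl on this nitrogen to a large drop: the limit of < 36 mL/min/kg in this assay, at which 3 of the 4 values shown sit.

As far as these compounds go, how compound 4 ranks against compound 1 and compound 2 stays open, as all three are limits. An acetyl or a plain methyl on the same nitrogen would show whether the carbonyl or the cyclopropyl ring goes with the step.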